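The compounds below may be only part of what the source reports. "The series", "measured", "known", "first", "only" and "open" are said of these compounds alone.

Working list for an ADME assay on the whole organism for pharmacokinetics, with Mus musculus as the target, at a dose of 10 mg/kg by the oral route (a higher number here means more compound in the circulation at the dose given, a lower number less compound in the circulation), follows.
- compound 1 `CC/C(=C(/c1ccc(/C=C/C(=O)O)cc1)c1ccc2[nH]ncc2c1)c1ccccc1C` gives 7200 ng.h/mL in this series
- compound 2 `CC/C(=C(/c1ccc(/C=C/C(=O)O)cc1)c1ccc2[nH]ncc2c1)c1ccc(C#N)cc1C` gives 4300 ng.h/mL in this series
- compound 3 `CC/C(=C(/c1ccc(/C=C/C(=O)O)cc1)c1ccc2[nH]ncc2c1)c1ccncc1Cl` has no value yet

The two measured compounds stand within the scatter of each other (a 1.7-fold lower number from compound 1 to compound 2 (0.22 log units; within the scatter)). Compound 3 replaces the 4-cyano-2-methylphenyl of compound 2 with 3-chloropyridin-4-yl (3-chloropyridin-4-yl in place of 4-cyano-2-methylphenyl on a double-bonded chain carbon bound to a double-bonded chain carbon and a saturated chain carbon). That single measured step covers only the cyano part of this exchange and offers no direction. In this assay no step beyond the scatter is expected (estimated: a 1.2-fold lower number from compound 2 to compound 3 (0.09 log units; within the scatter)). Compound 3 is estimated at 3500 ng.h/mL (expected range 1300 ng.h/mL to 9000 ng.h/mL).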

Compound 3, area under the concentration-time curve: 110 ng.h/mL
The estimate for compound 3 lay 32-fold (1.50 log units) above the measured number; measured number below the stated range.
By their numbers in this assay, from the lowest: compound 3; then compounds 2 and 1 (each within the scatter of the next).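

In this assay, the place on a double-bonded chain carbon bound to a double-bonded chain carbon and a saturated chain carbon proves sensitive to the aromatic group it carries: 3-chloropyridin-4-yl in place of 4-cyano-2-methylphenyl gives a large step (a 39-fold lower number from compound 2 to compound 3 (1.59 log units; beyond the scatter)), and in place of 2-methylphenyl another (a 65-fold lower number from compound 1 to compound 3 (1.82 log units; beyond the scatter)). Going by these compounds alone, the earlier nitrile change at this group gave no such step. No available measurement bears on the cause.

Ring nitrogen and chlorine enter together, so their separate contributions remain unresolved. Open, as far as these compounds go, is how 2-chlorophenyl or 3-methylpyridin-4-yl would read here.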